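Cytotoxicity working notes on a phenolic amide series

The source may hold more compounds than are shown below. What is called first, only, known or untested is meant among the compounds shown, and "the series" means these compounds.

compound 1 `O=C(O)/C=C/c1cc(O)c(O)c(O)c1`: 39100 nM
compound 2 `CCCCCCNC(=O)/C=C/c1ccc(O)c(O)c1`: 22600 nM

In a functional assay on C2BBe1 cells (Homo sapiens) for cytotoxicity, read by sulforhodamine B assay, with a stated time of 96 h (a lower number here means a stronger inhibitor, a higher number a weaker inhibitor), compound 1 gives 39100 nM, while compound 2 gives 22600 nM. Compound 2 carries the lowest of the two numbers, but its gap to compound 1 lies within the scatter, so no order between them is claimed.

Compound 3 `CCCCCCNC(=O)/C=C/c1cc(O)c(O)c(O)c1` is not yet measured. Relative to compound 2 the change is hydroxy in place of hydrogen on an aromatic carbon. Going by the values given here, no measured pair isolates this change, so any expectation rests on the two values alone. The step is expected to be small, a 1.3-fold lower number from compound 2 to compound 3 (0.10 log units; within the scatter), with no direction beyond the scatter. Compound 3 is estimated at 18000 nM, within 7000 nM to 45000 nM.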

Compound 3, half-maximal inhibitory concentration: 50900 nM
Estimate against measurement, compound 3: 2.8-fold (0.45 log units) below; measured number outside the range, above it.
By their numbers in this assay, from the lowest: compounds 2, 1 and 3 (each within the scatter of the next, the first and the last beyond it).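

In this assay, hydroxy in place of hydrogen on an aromatic carbon, ortho to a hydroxy group and meta to a large group, gives a 2.3-fold higher number from compound 2 to compound 3 (0.35 log units; beyond the scatter). Going by these compounds alone, this is the first single-place change that can be read, and at this position it yields a weaker inhibitor, not a stronger one. No measurement at hand accounts for the step. As far as these compounds go, whether a methoxy group at this position, or a longer chain on the amide nitrogen, would shift the number remains open.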